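Aryl urea series: human liver microsomal clearance notes

This account rests on a few compounds, and the source may have more. Where it says the series, first, only, none or still open, it means among the compounds named here.

Measured compounds:
- compound 1, `N#Cc1ccc(NC(=O)Nc2ccnc(C(F)(F)F)c2)cc1`: in an ADME assay on microsomes from liver (Homo sapiens) for metabolic stability, using NADPH, with a stated time of 60 min (on this read-out lower numbers stand for slow clearance and higher numbers for fast clearance), compound 1 gives < 7 uL/min, which is a limit of the assay.
- compound 2, `O=C(Nc1ccc(C(=O)O)cc1)Nc1ccc(F)c(C(F)(F)F)c1`: compound 2 gives < 7 uL/min, also a limit of the assay.
- compound 3, `O=C(Nc1ccc(F)c(C(F)(F)F)c1)Nc1cnccn1`: compound 3 gives 210 uL/min.

Among the compounds with values here, compound 3 therefore carries the only numerical value in the set; the other two sit at the limit of < 7 uL/min in this assay, at which 2 of the 3 values shown sit, so compound 3 cannot be ranked against them beyond saying its clearance is measurable. Compound 4, `O=C(Nc1ccc(F)c(C(F)(F)F)c1)Nc1ccccn1`, differs from compound 3 in one place: pyridin-2-yl in place of pyrazin-2-yl on an amide-type nitrogen. Within the data shown here, no measured pair shares this difference, so no measured step guides it. The expected step in this assay is a 1.1-fold higher number from compound 3 to compound 4 (0.04 log units; within the scatter), within the usual scatter. Compound 4 is expected to give 230 uL/min, with a range from 80 uL/min to 550 uL/min.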

Compound 4, intrinsic clearance in a liver preparation (reported as CLH), per the amount of preparation that the assay uses: 188 uL/min
Beside the measured number, compound 4's estimate is 1.2-fold (0.09 log units) above it; measured number inside the range.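

Within the data shown here, replacing pyrazin-2-yl with pyridin-2-yl on an amide-type nitrogen gives the first step that can be read in this assay, namely a 1.1-fold lower number from compound 3 to compound 4 (0.05 log units; within the scatter), so this change does not separate the two compounds. At this position, the two six-membered aromatic rings tested so far therefore give numbers within the scatter of each other. Nothing at hand bears on why this read-out stays unchanged across the pair.

Open, going by these compounds, is whether a phenyl or pyrimidin-2-yl group on the same nitrogen would stay within the scatter of compound 3. Also open, on these data alone, is whether a carboxylic acid or an amine on the pyridin-2-yl ring would shift the read-out.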